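The source may report more compounds than this note shows. Statements on the series, on what has been measured and on what is new or still open speak of the compounds shown alone.

In a functional assay on MCF7 cells (Homo sapiens) for antiproliferative activity, read by MTT assay, with a stated time of 48 h (on this read-out higher numbers stand for weaker inhibition and lower numbers for stronger inhibition), compound 1 (`COc1ccc(-c2nn(-c3ccccc3)cc2-c2nc3cc(F)ccc3[nH]2)cc1`) gives 1510 nM and compound 2 (`COc1ccc(-c2nn(-c3ccccc3)cc2-c2nc3cc(Cl)ccc3[nH]2)cc1`) gives 1760 nM so compound 2 stands level with compound 1 within the scatter. Compound 3 (`COc1ccc(-c2nn(-c3ccccc3)cc2-c2nc3cc(C)ccc3[nH]2)cc1`) carries methyl in place of chloro on an aromatic carbon. Going by the values given here, the one measured step at that place, chloro in place of fluoro, is a 1.2-fold higher number from compound 1 to compound 2 (0.07 log units; within the scatter) and no measured step involves methyl. In this assay no shift beyond the scatter is therefore expected. The estimate is a 1.1-fold lower number from compound 2 to compound 3 (0.04 log units; within the scatter) as an expected step. Compound 3 is expected at 1600 nM (estimated range 650 nM to 3800 nM).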

Compound 3, half-maximal inhibitory concentration: 6610 nM
Beside the measured number, compound 3's estimate is 4.1-fold (0.62 log units) below it; measured number outside the range, above it.
By their numbers in this assay, from the lowest: compounds 1 and 2 (each within the scatter of the next); then compound 3.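

In this assay, this position on the aromatic carbon proved sensitive to the group it carries: fluoro and chloro stood level, but methyl gives a 3.8-fold higher number from compound 2 to compound 3 (0.57 log units; beyond the scatter) and a 4.4-fold higher number from compound 1 to compound 3 (0.64 log units; beyond the scatter). A swap of one heavy atom for another is thus enough to weaken inhibition beyond the scatter, which the halogen pair alone did not reveal. No available evidence accounts for this difference. From the compounds shown here alone, whether a longer chain such as ethyl, an amine or a carboxylic acid at this carbon would fare like methyl or like the halogens remains open.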